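From 3,4-dimethoxyphenyl to phenyl in a growth test

The source may report more compounds than this note shows. Statements on the series, on what has been measured and on what is new or still open speak of the compounds shown alone.

- Compound 1 (`COc1ccc(/C=C/C(=O)/C=C/c2ccc(OCc3cn(CCCCCOc4cc(=O)oc5ccccc45)nn3)c(OC)c2)cc1OC`) gives 43%
- Compound 2 (`COc1cc(/C=C/C(=O)/C=C/c2ccco2)ccc1OCc1cn(CCCCOc2cc(=O)oc3ccccc23)nn1`) gives 43%

In a functional assay on COLO 205 cells (Homo sapiens) for inhibition, read by sulforhodamine B assay, with a stated time of 48 h, tested at 50 uM (a higher number here means more inhibition of growth at the concentration tested, a lower number less inhibition of growth), compound 1 stands level with compound 2, within the scatter. Compound 3 (`COc1cc(/C=C/C(=O)/C=C/c2ccccc2)ccc1OCc1cn(CCCCCOc2cc(=O)oc3ccccc23)nn1`) keeps the rest of compound 1 but has phenyl in place of 3,4-dimethoxyphenyl on a double-bonded chain carbon bound to a double-bonded chain carbon. Going by the values given here, no measured pair shows this change alone, so the direction is uncertain. The estimated change is a number 2 percentage points higher from compound 1 to compound 3 (within the scatter) in this assay, which is no step beyond the scatter. For compound 3 the estimated value is 45% with an expected range from 28% to 62% in this test.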

Compound 3, percent growth inhibition at one concentration: 22%
Beside the measured number, compound 3's estimate is 23 percentage points above it; the whole stated range lies above it.
By their numbers in this assay, from the lowest: compound 3; then compounds 1 and 2 (each within the scatter of the next).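

Replacing 3,4-dimethoxyphenyl with phenyl on a double-bonded chain carbon bound to a double-bonded chain carbon is not a neutral swap: in this assay it gives a number 21 percentage points lower from compound 1 to compound 3 (beyond the scatter) with the rest of compound 1 unchanged. Compound 1 and compound 2 differ in more than one place, so they could not isolate this change. Nothing available here explains the drop. The compounds shown leave open whether a single methoxy group on the phenyl would be enough to hold the level of compound 1, and how a hydroxyl or a dimethylamino group there would compare.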